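Replacing isopropyl with pyridinylmethyl on the piperazine nitrogen

This account rests on a few compounds, and the source may have more. Where it says the series, first, only, none or still open, it means among the compounds named here.

Compound 1 `CCN1CCN(S(=O)(=O)CCCN2CCC(CNC(=O)c3cccc4c3OCCO4)CC2)CC1` and compound 2 `CC(C)N1CCN(S(=O)(=O)CCCN2CCC(CNC(=O)c3cccc4c3OCCO4)CC2)CC1` share one core and differ only at the amine nitrogen in the piperazine ring. In an assay on isolated protein for inhibition of 5-hydroxytryptamine receptor 4 (Homo sapiens) (on this read-out lower numbers stand for stronger inhibition and higher numbers for weaker inhibition), compound 1 gives 0.0501 nM, and compound 2 gives 0.0316 nM. The step of a 1.6-fold lower number from compound 1 to compound 2 (0.20 log units; within the scatter) lies within the scatter, so compound 2 has the lower of the two numbers without standing apart from compound 1.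

Compound 3 `O=C(NCC1CCN(CCCS(=O)(=O)N2CCN(Cc3cccnc3)CC2)CC1)c1cccc2c1OCCO2` changes the same position: (pyridin-3-yl)methyl in place of isopropyl on an amine nitrogen in a ring. Going by the values given here, the only measured step, a 1.6-fold lower number from compound 1 to compound 2 (0.20 log units; within the scatter), concerns a far smaller change at this nitrogen and showed nothing beyond the scatter; no step involving an aromatic group at this place is known. Compound 3 is therefore expected to stay near compound 2, with the step of a 1.9-fold higher number from compound 2 to compound 3 (0.28 log units; within the scatter) carrying a wide uncertainty. In this assay compound 3 is estimated at 0.06 nM, within 0.012 nM to 0.3 nM.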

Compound 3, inhibition constant: 0.159 nM
The estimate for compound 3 lay 2.7-fold (0.42 log units) below the measured number; the measured number falls inside the stated range.
By their numbers in this assay, from the lowest: compounds 2 and 1 (each within the scatter of the next); then compound 3.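

In this assay, going by these compounds alone, (pyridin-3-yl)methyl on the amine nitrogen in a ring gives the first steps at this position that lie beyond the scatter: a 5.0-fold higher number from compound 2 to compound 3 (0.70 log units; beyond the scatter), and a 3.2-fold higher number from compound 1 to compound 3 (0.50 log units; beyond the scatter). The position therefore does respond to its substituent, which the pair compound 1 and compound 2 could not show, although both steps are modest. No available evidence bears on why the number rises with this change.

The compounds shown leave open whether the higher number goes with the six-membered aromatic ring itself or with the nitrogen in that ring, and a benzyl group at this place would separate the two. They also leave open how a cyclohexylmethyl group, which carries a saturated ring instead, would compare with isopropyl and (pyridin-3-yl)methyl.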